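Replacing the bromophenyl of compound 3 with a substituted pyrrole

The source may hold more compounds than are shown below. What is called first, only, known or untested is meant among the compounds shown, and "the series" means these compounds.

Of the compounds shown here, three on a shared core have been tested in a functional assay on A549 cells (Homo sapiens) for antiproliferative activity, read by MTT assay, with a stated time of 72 h; a higher number here means a weaker inhibitor, a lower number a stronger inhibitor. Compound 3 `O=C(N/N=C/c1ccc(Br)cc1)Nc1ccc(Oc2ccnc3[nH]ccc23)cc1` gives 640 nM, the lowest of the three numbers seen so far. Compound 1 `O=C(N/N=C/c1ccc(Br)cc1)Nc1ccc(Oc2ccnc3[nH]ccc23)c(F)c1` gives 820 nM, and the difference to compound 3 is a 1.3-fold lower number from compound 1 to compound 3 (0.11 log units; within the scatter), which is within the scatter, so the two cannot be separated. Compound 2 `COc1ccc(/C=N/NC(=O)Nc2ccc(Oc3ccnc4[nH]ccc34)c(F)c2)cc1` gives 3980 nM; here the difference is a 4.9-fold higher number from compound 1 to compound 2 (0.69 log units; beyond the scatter), a modest step beyond the scatter.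

Compound 4 `CN(C)CCCn1cccc1/C=N/NC(=O)Nc1ccc(Oc2ccnc3[nH]ccc23)cc1` is the next one to be measured in this assay. It differs from compound 3 in one place: 1-(3-(dimethylamino)propyl)-1H-pyrrol-2-yl in place of 4-bromophenyl on a carbon with a double bond to nitrogen. Going by the values given here, only one measured step touches the group on the carbon with a double bond to nitrogen, namely a 4.9-fold higher number from compound 1 to compound 2 (0.69 log units; beyond the scatter), where exchanging the bromo for a methoxy weakened the inhibitor. Nothing measured bears on the entering 1-(3-(dimethylamino)propyl)-1H-pyrrol-2-yl group, and the present exchange replaces the whole ring. On that basis, compound 4 is expected to be a weaker inhibitor than compound 3 by a 3.1-fold higher number from compound 3 to compound 4 (0.49 log units; beyond the scatter) in this assay, with wide uncertainty. The estimate for compound 4 in this assay is 2000 nM, with a range from 500 nM to 8000 nM.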

Compound 4, half-maximal inhibitory concentration: 2660 nM
For compound 4 the middle estimate is 1.3-fold (0.12 log units) below the measured one; low and high end bracket the measured number.
By their numbers in this assay, from the lowest: compounds 3 and 1 (each within the scatter of the next); then compounds 4 and 2 (each within the scatter of the next).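

In this assay, the step at the carbon with a double bond to nitrogen is a 4.2-fold higher number from compound 3 to compound 4 (0.62 log units; beyond the scatter), and it comes from exchanging the whole 4-bromophenyl ring rather than only a substituent on it. Together with the earlier 4.9-fold higher number from compound 1 to compound 2 (0.69 log units; beyond the scatter), this means that both measured changes that remove the bromo at this position give a higher number, and no compound shown goes against that, although only these two steps support it and they start from different parents. Compound 4 also shows that a 1-(3-(dimethylamino)propyl)-1H-pyrrol-2-yl group, with its five-membered ring and more heavy atoms than the group it replaces, still gives a measurable value of 2660 nM, while nothing available explains the size of the step.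

The five-membered ring and the dimethylaminopropyl chain enter together, so the compounds shown cannot say how much of the step belongs to either part. A pyrrole carrying only a methyl on its nitrogen, or a chain ending in a morpholine rather than a dimethylamino group, would begin to separate the two.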